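Acetyl to (hydroxymethyl)carbonyl in the series

This account rests on a few compounds, and the source may have more. Where it says the series, first, only, none or still open, it means among the compounds named here.

In an ADME assay on microsomes from liver (Mus musculus) for metabolic stability, with a stated time of 10 min (a lower number here means that less of the compound is left, a higher number that more of the compound is left), compound 1 (`C[C@]1(c2ccc(F)cc2)CN(C(=O)NCc2ccncc2)C[C@H]1c1ccc(C(O)(C(F)(F)F)C(F)(F)F)cc1`) gives 1% and compound 2 (`CC(=O)N1CCC(C(=O)N2C[C@@H](c3ccc(C(O)(C(F)(F)F)C(F)(F)F)cc3)[C@@](C)(c3ccc(F)cc3)C2)CC1`) gives 81%, the higher of the two numbers. Compound 3 (`C[C@]1(c2ccc(F)cc2)CN(C(=O)C2CCN(C(=O)CO)CC2)C[C@H]1c1ccc(C(O)(C(F)(F)F)C(F)(F)F)cc1`) departs from compound 2 by hydroxy in place of hydrogen on a saturated chain carbon bound to a carbonyl carbon, turning acetyl into (hydroxymethyl)carbonyl. Among the measured compounds shown here, the only measured step, a number 80 percentage points higher from compound 1 to compound 2 (beyond the scatter), is large but comes with 1-acetylpiperidin-4-yl in place of ((pyridin-4-yl)methyl)amino on a carbonyl carbon, a different change, so it bears only loosely here. For the measured compounds named here, no measured step covers this hydroxy change, and only a small drop, within the scatter, is expected: a number 5 percentage points lower from compound 2 to compound 3 (within the scatter). For compound 3 the estimated value is 76%, with an expected range of 52% to 94%.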

Compound 3, percent of the compound remaining: 82%
Compound 3: middle estimate off by 6 percentage points, on the low side, and the stated range covers the measured number.
By their numbers in this assay, from the lowest: compound 1; then compounds 2 and 3 (each within the scatter of the next).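

In this assay hydroxy in place of hydrogen on a saturated chain carbon bound to a carbonyl carbon is accommodated, with a number 1 percentage points higher from compound 2 to compound 3 (within the scatter) as the step. Among the compounds shown here, the large step from the pyridine-bearing urea also holds with the new group, with a number 81 percentage points higher from compound 1 to compound 3 (beyond the scatter) as the step, so acetyl is not the only end group on this piperidine that gives a high number. No measurement available here accounts for either step.

Open, on these data alone, is whether an amine or a carboxylic acid in place of the hydroxy, or a longer chain carrying it, would keep the number in this assay this high.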